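The source may report more compounds than this note shows. Statements on the series, on what has been measured and on what is new or still open speak of the compounds shown alone.

Working notes on the series. In an assay on HEK293 cells for agonist activity at Bile acid receptor (Homo sapiens) (a higher number here means that more compound is needed for the effect, a lower number that less compound is needed), compound 1 `CS(=O)(=O)NC(=O)c1ccc([C@@H]2C[C@H]2c2ccc(OCc3c(-c4c(Cl)cccc4Cl)noc3C3CC3)cc2Cl)cc1` gives 44 nM, the highest of the three numbers; compound 3 `O=C(O)c1cccc(C2CC2c2ccc(OCc3c(-c4c(Cl)cccc4Cl)noc3C3CC3)cc2Cl)c1` gives 34 nM, within the scatter of compound 1, while compound 2 `CC(C)n1nc(C(=O)O)cc1[C@@H]1C[C@H]1c1ccc(OCc2c(-c3c(Cl)cccc3Cl)noc2C2CC2)cc1Cl` gives 4 nM, the only one beyond it. Compound 4 `CS(=O)(=O)NC(=O)c1ccc(C2CC2c2ccc(OCc3c(-c4c(Cl)cccc4Cl)noc3C3CC3)cc2Cl)cc1` has not been measured; the two compounds have the same atoms and bonds; at least one stereo element is drawn with a configuration in one of them and without one in the other: 2 of 2 stereo elements differ; a stereocentre at a saturated ring carbon is drawn R in compound 1 and without a configuration in compound 4; a stereocentre at a saturated ring carbon is drawn R in compound 1 and without a configuration in compound 4 compound 4 is therefore the same material without a drawn configuration at either saturated ring carbon. Going by the values given here, no measured pair in the set traces this kind of change, so the step is estimated, not derived; an undefined stereo drawing is expected to give a number at or somewhat above compound 1, a step of a 1.6-fold higher number from compound 1 to compound 4 (0.20 log units; within the scatter) that sits within or just beyond the scatter. For compound 4 the expected value in this assay is 70 nM, within a range from 30 nM to 200 nM.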

Compound 4, half-maximal effective concentration: 44 nM
Beside the measured number, compound 4's estimate is 1.6-fold (0.20 log units) above it; measured number inside the range.
By their numbers in this assay, from the lowest: compound 2; then compounds 3, 1 and 4 (each within the scatter of the next).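

Going by these compounds alone, the only traced step is a drawing change at the two saturated ring carbons, and in this assay it gives no change at the digits printed from compound 1 to compound 4 (within the scatter). With the rest of the structure shared, this comparison isolates the drawn configuration: the fact that one of compounds 1 and 4 is drawn with a defined configuration and the other without, at the place where they differ. An undefined drawing therefore costs nothing measurable here, but it does not show that configuration is unimportant, since the composition of the undrawn material is not stated. Still open, from the compounds shown here alone, is how the opposite configuration at both ring carbons reads, and whether a tetrazole in place of the acyl sulfonamide holds the number.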